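Sulfone Series Against DU-145 Growth, Aryl Change Noted

A few compounds are considered here, and "the series" means these few. Any claim that something is new, unique, unknown or untested is made for them only; others in the source may bear on it.

Compound 1 `Cc1ccc(CS(=O)(=O)/C(=C/c2ccc(Br)cc2)C(=O)c2ccc(Cl)cc2)cc1`: 25000 nM
Compound 2 `CCOc1cc(/C=C(\C(=O)c2ccc(Cl)cc2)S(=O)(=O)Cc2ccc(Cl)cc2)ccc1O`: 10000 nM
Compound 3 `Cc1ccc(CS/C(=C/c2cc(C)ccc2C)C(=O)c2ccc(Cl)cc2)cc1`: 10000 nM

All three were read in a functional assay on DU-145 cells (Homo sapiens) for inhibition, read by trypan blue exclusion, with a stated time of 96 h; on this read-out higher numbers stand for weaker inhibition of growth and lower numbers for stronger inhibition of growth. Compound 1 gives the highest number of the three, weaker inhibition of growth than compound 2 and compound 3, and each of those gaps lies beyond the scatter. The unmeasured compound 4 `Cc1ccc(CS(=O)(=O)/C(=C/c2cc(C)ccc2C)C(=O)c2ccc(Cl)cc2)cc1` differs from compound 1 by 2,5-dimethylphenyl in place of 4-bromophenyl on a double-bonded chain carbon bound to a double-bonded chain carbon. For the measured compounds named here, no measured pair isolates this one change. Compound 3, which carries the same 2,5-dimethylphenyl group on a different core, gives 10000 nM. Compound 4 is expected to give a lower number than compound 1, a step of a 2.1-fold lower number from compound 1 to compound 4 (0.32 log units; beyond the scatter) at about the edge of the scatter. The estimate for compound 4 is 12000 nM, with a range from 4000 nM to 40000 nM.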

Compound 4, concentration for 50% growth inhibition: 1000 nM
Beside the measured number, compound 4's estimate is 12-fold (1.08 log units) above it; measured number outside the range, below it.
By their numbers in this assay, from the lowest: compound 4; then compounds 2 and 3 (each within the scatter of the next); then compound 1.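

On a double-bonded chain carbon bound to a double-bonded chain carbon, 2,5-dimethylphenyl in place of 4-bromophenyl gives a 25-fold lower number from compound 1 to compound 4 (1.40 log units; beyond the scatter) in this assay, so the shared core responds strongly to the aryl group at this position. The group does not set the number by itself: compound 3, on a different core, gives 10000 nM and compound 4 gives 1000 nM on the sulfone core. No measurement here accounts for the size of the step. Open, as far as these compounds go, is whether the methyl groups or the absence of bromine drives the drop, and whether a methoxy or an amine on this phenyl ring keeps the low number.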